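This account rests on a few compounds, and the source may have more. Where it says the series, first, only, none or still open, it means among the compounds named here.

Three compounds built on a shared core were tested in a functional assay on HL-60 cells (Homo sapiens) for cytotoxicity, read by XTT assay, with a stated time of 72 h; a higher number here means a weaker inhibitor, a lower number a stronger inhibitor. Compound 1 `CCCCCCCCCCCCCCCCCCOc1cc(O)cc(O)c1C(C)=O` gives only a limit of the assay, > 100000 nM. Compound 2 `CC(=O)c1c(O)c(CC=C(C)C)c(O)c(CC=C(C)C)c1O` also gives a limit, > 100000 nM. Compound 3 `CCCCCCCCCCCCCCCCCCOc1cc(O)c(C(C)=O)c(O)c1` likewise reaches a limit, > 100000 nM. Thus compound 3 stands exactly where the other two stand, at the limit of > 100000 nM in this assay, at which 3 of the 3 values shown sit; no number separates them, and no step between measured compounds can be drawn from these values alone.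

The next compound, compound 4 `CCCCCCCC/C=C\CCCCCCCCOc1cc(O)c(C(C)=O)c(O)c1`, differs from compound 3 in one place: dec-1-en-1-yl in place of decyl on a saturated chain carbon, eight bonds along the chain from an oxygen on an aromatic ring. The aromatic ring and its substituents are untouched; only the long chain is altered. With nothing but limits to build on, no shift beyond the usual scatter is expected in this assay, and compound 4 is estimated to give 120000 nM, in a range from 40000 nM to 300000 nM, most probably once more as a limit only. The expected step that the limit leaves unreadable from compound 3 to compound 4 is therefore essentially none.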

Compound 4, half-maximal inhibitory concentration: 32000 nM
Estimate against measurement, compound 4: 3.8-fold (0.57 log units) above; the whole stated range lies above it.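

In this assay, the long chain turns out to be a place where a single change can be read: dec-1-en-1-yl in place of decyl gives an at least 3.1-fold lower number from compound 3 to compound 4 (0.49 log units; beyond the scatter). The earlier compounds shown here showed no difference at all, whereas here one double bond outside aromatic rings, with the same count of carbons in the group, is enough to yield a measured number. The size of this step is only a minimum, because compound 3 has no number of its own: the limit of > 100000 nM in this assay, at which 3 of the 4 values shown sit.

From the compounds shown here alone, it remains open whether moving the double bond to another place along the chain would give a similar result, and whether a shorter chain, a longer chain, or a chain ending in an amine or a carboxylic acid would lower the number further. The same change on the chain of compound 1 also remains untested among the compounds shown here.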